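Oxane substituent swap on a pyrazole calcium channel inhibitor

This account rests on a few compounds, and the source may have more. Where it says the series, first, only, none or still open, it means among the compounds named here.

Compound 1 `COc1ccccc1-n1nc([C@@H]2CCO[C@@H](C(C)C)C2)cc1-c1ccc(Cl)cc1`: an assay on HEK293 cells for inhibition of Voltage-dependent N-type calcium channel subunit alpha-1B (Homo sapiens), read by patch clamp, using a membrane potential dye; a lower number here means a stronger inhibitor, a higher number a weaker inhibitor "not determined" (no result reported)
Compound 2 `CCOc1ccc(-c2cc(C3CC(C)(C)OC(C)(C)C3)nn2-c2ccccc2OC)cc1`: this assay 61 nM
Compound 3 `COc1ccccc1-n1nc(C2CC(C)(C)OC(C)(C)C2)cc1-c1csc(Cl)c1`: this assay 62 nM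

In this assay compound 1 has no reported result, so it stands nowhere on the numbers shown. Compound 4 `COc1ccccc1-n1nc([C@H]2C[C@@H](C)O[C@@H](C)C2)cc1-c1ccc(Cl)cc1` differs from compound 1 in one place: 2,6-dimethyloxan-4-yl in place of 2-isopropyloxan-4-yl on an aromatic carbon. For the measured compounds named here, no measured step touches this part of the core; the only step available, a 1.0-fold higher number from compound 2 to compound 3 (0.01 log units; within the scatter), changes the aromatic group on the other side of the core and sits within the scatter. It therefore says nothing about the direction or size of the change from compound 1 to compound 4, and the expectation rests on compounds 2 and 3, which carry a related saturated group at the same place: compound 2 gives 61 nM and compound 3 gives 62 nM. Because compound 3 gives 62 nM with a chlorinated aromatic group, compound 4 is expected to lie in the same region in this assay. Compound 4 is estimated at 75 nM, within a range from 20 nM to 300 nM.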

Compound 4, half-maximal inhibitory concentration: 91 nM
Beside the measured number, compound 4's estimate is 1.2-fold (0.08 log units) below it; low and high end bracket the measured number.
By their numbers in this assay, from the lowest: compounds 2, 3 and 4 (each within the scatter of the next).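

In this assay, for the compounds shown here, compound 1 stands at "not determined" (no result reported), and no step to compound 4 can be read from it. The compounds shown leave open what 2,6-dimethyloxan-4-yl in place of 2-isopropyloxan-4-yl does to the number. Nothing shown accounts for the value of compound 4.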